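The compounds below may be only part of what the source reports. "The series", "measured", "known", "first", "only" and "open" are said of these compounds alone.

Measured in an ADME assay on BJ cells (Homo sapiens), read by MTT assay, with a stated time of 72 h; a higher number here means a weaker inhibitor, a lower number a stronger inhibitor:
- Compound 1 (`Nc1nc(N)c2c(-c3cccs3)cn([C@@H]3O[C@H](CO)[C@@H](O)[C@H]3O)c2n1`) gives > 100000 nM as a limit.
- Compound 2 (`Cc1nc(N)c2c(-c3ccoc3)cn([C@@H]3O[C@H](CO)[C@@H](O)[C@H]3O)c2n1`) gives > 100000 nM as a limit.
- Compound 3 (`Cc1nc(N)c2c(-c3cccs3)cn([C@@H]3O[C@H](CO)[C@@H](O)[C@H]3O)c2n1`) gives > 100000 nM as a limit.

Compound 3 has no numerical value, and neither does either of the other two compounds: all sit at the same limit (the limit of > 100000 nM in this assay, at which 3 of the 3 values shown sit). The next change leads to compound 4 (`Cc1nc(N)c2c(-c3cc4ccccc4o3)cn([C@@H]3O[C@H](CO)[C@@H](O)[C@H]3O)c2n1`), with 1-benzofuran-2-yl in place of thiophen-2-yl on an aromatic carbon. Within the data shown here, the entering group brings a six-membered aromatic ring of carbon only, which none of the measured compounds carries.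

Two measured steps reach compound 3. Among the measured compounds shown here, the first is a step that the two limits leave unreadable from compound 1 to compound 3, with methyl in place of amino on an aromatic carbon. The second is a step that the two limits leave unreadable from compound 2 to compound 3, with thiophen-2-yl in place of furan-3-yl on an aromatic carbon. The second step is the closer precedent, since it also exchanges the group at this place, but neither step gives a size to carry forward.

The most likely result is therefore another limit, and any readable value is expected toward stronger inhibition. The estimated step is a number no higher from compound 3 to compound 4 (the limit leaves the size open) in this assay and remains weakly grounded. For compound 4 the expected value is 100000 nM with an estimated range from 25000 nM to 200000 nM in the same assay.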

Compound 4, half-maximal inhibitory concentration: > 100000 nM
Compound 4: a limit, no number (the forecaster's own chance of this, stated with the estimate: 75%); the middle value lies on the limit itself.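

In this assay compound 4 gives > 100000 nM, a limit and not a number. The steps from compound 2 and from compound 3 to compound 4 therefore cannot be read: the limit of > 100000 nM in this assay, at which 4 of the 4 values shown sit. The compounds shown leave open whether any group at this place gives a readable value in this assay.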